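The source may report more compounds than this note shows. Statements on the series, on what has been measured and on what is new or still open speak of the compounds shown alone.

Compound 1 `C=C[C@@](C)(/C=C/c1ccc(OCc2cn(Cc3ccc(Cl)cc3)nn2)cc1)CCC=C(C)C` and compound 2 `C=C[C@@](C)(/C=C/c1ccc(OCc2cn(Cc3ccc(F)cc3)nn2)cc1)CCC=C(C)C` share a core and differ only in fluoro in place of chloro on an aromatic carbon. In a toxicity assay on RAW264.7 cells (Mus musculus) for cytotoxicity, read by MTT assay, with a stated time of 24 h (a higher number here means a weaker inhibitor, a lower number a stronger inhibitor), compound 1 gives 327000 nM, and compound 2 gives 157000 nM, so that a 2.1-fold lower number from compound 1 to compound 2 (0.32 log units; beyond the scatter). Compound 3 `C=C[C@@](C)(/C=C/c1ccc(OC(=O)c2cn(-c3ccc(Cl)cc3)nn2)cc1)CCC=C(C)C` gives 115000 nM in this assay; how its core differs from that of compound 1 is not broken down here. Compound 4 `C=C[C@@](C)(/C=C/c1ccc(OC(=O)c2cn(-c3ccc(F)cc3)nn2)cc1)CCC=C(C)C` differs from compound 3 by fluoro in place of chloro on an aromatic carbon, the same change seen from compound 1 to compound 2, made at the same kind of place. Because the earlier step was a 2.1-fold lower number from compound 1 to compound 2 (0.32 log units; beyond the scatter), a step of comparable size is expected here, so that a 1.8-fold lower number from compound 3 to compound 4 (0.25 log units; within the scatter). Compound 4 is therefore estimated at 65000 nM in this assay, with a likely range from 30000 nM to 140000 nM.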

Compound 4, half-maximal inhibitory concentration: 79900 nM
The estimate for compound 4 lay 1.2-fold (0.09 log units) below the measured number; measured number inside the range.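

In this assay, fluoro in place of chloro on the core of compound 3 gives a 1.4-fold lower number from compound 3 to compound 4 (0.16 log units; within the scatter). Set beside the same change on the core of compound 1, the two steps do not measurably differ: the same change on two cores in this assay, a 2.1-fold lower number (0.32 log units; beyond the scatter) from compound 1 to compound 2 and a 1.4-fold lower number (0.16 log units; within the scatter) from compound 3 to compound 4, 1.4-fold (0.16 log units) apart, within the scatter of two such steps. Among these compounds, this supports carrying the change between these two cores, but it rests on only two pairs in one assay, and it does not show that the change lowers the number on every core.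

The compounds shown leave open what other groups at this place, such as bromo, methyl, methoxy or an amine, would do on either core. They also leave open whether the change carries over to cores beyond these two.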